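The source may report more compounds than this note shows. Statements on the series, on what has been measured and on what is new or still open speak of the compounds shown alone.

Measured so far in an ADME assay on Vero cells (Chlorocebus sabaeus) for cytotoxicity, read by MTT assay, with a stated time of 72 h; a lower number here means that less compound is tolerated, a higher number that more compound is tolerated: compound 1 `CCOC(=O)c1c(-c2ccc(OC)cc2)oc2ccc(OCCCCCCN3C(=O)C(=O)c4cc(F)ccc43)cc12` gives 128000 nM. Compound 2 `CCOC(=O)c1c(-c2ccccc2)oc2ccc(OCCCN3C(=O)C(=O)c4cc(OC)ccc43)cc12` gives 256000 nM. Compound 3 `CCOC(=O)c1c(-c2ccc(F)cc2)oc2ccc(OCCCN3C(=O)C(=O)c4cc(OC)ccc43)cc12` gives 128000 nM.

Compound 3 and compound 2 differ in one place, (hydrogen in place of fluoro on an aromatic carbon), and this gave a 2.0-fold higher number from compound 3 to compound 2 (0.30 log units; within the scatter). Compound 4 `CCOC(=O)c1c(-c2ccc(OC)cc2)oc2ccc(OCCCCCCN3C(=O)C(=O)c4ccccc43)cc12` is related to compound 1 by the same kind of change, (hydrogen in place of fluoro on an aromatic carbon). The two places are not identical: in compound 3 the fluoro sits on a six-membered aromatic ring of carbon only, para to a large group; in compound 1 it sits on a ring that is part of a fused or bridged system of two rings, meta to a fused ring and para to a fused ring. The difference between the cores of compound 1 and compound 3 is not broken down here; their readings in this assay agree at the digits read, and compound 2 lies within the scatter of both.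

For compound 4 a step of a 1.4-fold higher number from compound 1 to compound 4 (0.15 log units; within the scatter) is expected, resting on the earlier step of a 2.0-fold higher number from compound 3 to compound 2 (0.30 log units; within the scatter). Compound 4 is therefore estimated at 180000 nM.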

Compound 4, half-maximal cytotoxic concentration: 256000 nM
Compound 4: middle estimate off by 1.4-fold (0.15 log units), on the low side, within the range that was stated.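

In this assay, hydrogen in place of fluoro on an aromatic carbon gives a 2.0-fold higher number from compound 1 to compound 4 (0.30 log units; within the scatter). Set beside the earlier step, the change reads alike on the two cores: the same change on two cores in this assay, a 2.0-fold higher number (0.30 log units; within the scatter) from compound 3 to compound 2 and a 2.0-fold higher number (0.30 log units; within the scatter) from compound 1 to compound 4, 1.0-fold (0.00 log units) apart, within the scatter of two such steps. This shows that the change carried from one core to the other without a step beyond the scatter, but both steps lie within the scatter, so it does not show a real effect of the fluoro on tolerance, and two pairs, with the fluoro on different rings, give no general rule for the series.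

Open, as far as these compounds go, is whether an amine or a carboxylic acid in place of the fluoro would give a step beyond the scatter. Also open, from the compounds shown here alone, is whether such a step would carry between these cores.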